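Working notes: aryl swap on the ring nitrogen

The source may report more compounds than this note shows. Statements on the series, on what has been measured and on what is new or still open speak of the compounds shown alone.

Measured compounds:
- compound 1, `N#CC1=C(N)Oc2c(c3nc4ccccc4nc3c3ccccc23)C12C(=O)N(Cc1cnnn1-c1ccc([N+](=O)[O-])cc1)c1ccccc12`. In a functional assay on MCF7 cells (Homo sapiens) for antiproliferative activity, read by MTT assay, with a stated time of 48 h (on this read-out lower numbers stand for stronger inhibition and higher numbers for weaker inhibition), compound 1 gives > 50000 nM, a limit of the assay.
- compound 2, `N#CC1=C(N)Oc2c(c3nc4ccccc4nc3c3ccccc23)C12C(=O)N(Cc1cnnn1-c1ccc(Cl)c(Cl)c1)c1ccccc12`. In this assay compound 2 gives > 50000 nM, a limit of the assay.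
- compound 3, `Cc1ccccc1-n1nncc1CN1C(=O)C2(C(C#N)=C(N)Oc3c(N)cc4nc5ccccc5nc4c32)c2ccccc21`. In this assay compound 3 gives > 50000 nM, a limit of the assay.

Compound 3 therefore stands nowhere in particular among the numbers shown: every value in the set is the limit of > 50000 nM in this assay, at which 3 of the 3 values shown sit, and no compound can be placed above or below another.

Going by the values given here, the only step between measured compounds that differ in one place is a step that the two limits leave unreadable from compound 1 to compound 2; both ends are limits, so its size cannot be read.

The unmeasured compound 4 is `N#CC1=C(N)Oc2c(N)cc3nc4ccccc4nc3c2C12C(=O)N(Cc1cnnn1-c1ccc(Cl)cc1Cl)c1ccccc12`. It differs from compound 3 by 2,4-dichlorophenyl in place of 2-methylphenyl on an aromatic nitrogen. Among the compounds with values here, the one measured step in the same region, from compound 1 to compound 2, also exchanges the group on that aromatic nitrogen and tells nothing readable; no measured evidence bears on the direction or size of the present change.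

The expectation is that compound 4 stays at the limit in this assay, so the expected step that the limit leaves unreadable from compound 3 to compound 4 is none that can be read. For compound 4 the estimate is 70000 nM, with a range from 20000 nM to 250000 nM.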

Compound 4, half-maximal inhibitory concentration: > 50000 nM
Compound 4: only a limit was reported; the forecaster's own chance of this, stated with the estimate: 85%; the middle value is on the limit's open side.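

In this assay compound 4 gives > 50000 nM, a limit of the assay. With compound 3 also at a limit, no step can be read from compound 3 to compound 4, and the whole set rests on one value: the limit of > 50000 nM in this assay, at which 4 of the 4 values shown sit. The compounds shown leave open whether any group on that aromatic nitrogen gives a measurable value in this assay.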